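A few compounds are considered here, and "the series" means these few. Any claim that something is new, unique, unknown or untested is made for them only; others in the source may bear on it.

Working notes on the series. The shared core is that of compound 1 `COc1ccc(/C=C/c2cc(OC)cc(OC)c2/C=C/C(=O)N2CCC(Cl)CC2)cc1`, which in a functional assay on MCF7 cells (Homo sapiens) for inhibition, read by MTT assay, with a stated time of 48 h (a higher number here means a weaker inhibitor, a lower number a stronger inhibitor), gives 4950 nM. Compound 2 `COc1ccc(/C=C/c2cc(OC)cc(OC)c2/C=C/C(=O)N2CCCCC2)cc1` gives 6050 nM in this assay, and compound 3 `COc1ccc(/C=C/c2cc(OC)cc(OC)c2/C=C/C(=O)N2CCCC2)cc1` gives 4200 nM. Compound 1 stands second highest of the three numbers; its nearest neighbour is compound 3 and its furthest is compound 2, and both gaps are within the scatter. All measured steps are small: a 1.2-fold higher number from compound 1 to compound 2 (0.09 log units; within the scatter), a 1.2-fold lower number from compound 1 to compound 3 (0.07 log units; within the scatter), and a 1.4-fold lower number from compound 2 to compound 3 (0.16 log units; within the scatter).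

Compound 4 `COc1ccc(/C=C/c2cc(OC)cc(OC)c2/C=C/C(=O)N2CCN(C)CC2)cc1` is not yet measured. Its difference from compound 1: 4-methylpiperazin-1-yl in place of 4-chloropiperidin-1-yl on a carbonyl carbon. The step of a 1.2-fold higher number from compound 1 to compound 2 (0.09 log units; within the scatter) also alters the 4-chloropiperidin-1-yl group and bears on this change most directly; the steps to compound 3 show that exchanging the whole ring on the carbonyl carbon likewise left the number within the scatter. Going by the values given here, no measured step brings a 4-methylpiperazin-1-yl group onto the carbonyl carbon, and nothing in the data sets a direction for it. For compound 4 the step of a 1.0-fold higher number from compound 1 to compound 4 (0.00 log units; within the scatter) is therefore expected to stay within the scatter. Compound 4 is estimated at 5000 nM, with a range from 2000 nM to 12500 nM.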

Compound 4, half-maximal inhibitory concentration: 2290 nM
Compound 4: the middle estimate sits 2.2-fold (0.34 log units) above what was measured; the measured number falls inside the stated range.
By their numbers in this assay, from the lowest: compounds 4, 3, 1 and 2 (each within the scatter of the next, the first and the last beyond it).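

Going by these compounds alone, on the carbonyl carbon, 4-methylpiperazin-1-yl gives the first steps that lie beyond the scatter in this assay (a 2.2-fold lower number from compound 1 to compound 4 (0.33 log units; beyond the scatter) and a 2.6-fold lower number from compound 2 to compound 4 (0.42 log units; beyond the scatter)), so the number at this position does respond to the choice of ring, which the earlier exchanges among 4-chloropiperidin-1-yl, piperidin-1-yl and pyrrolidin-1-yl did not show. The separation is only partial and the size modest: against the pyrrolidin-1-yl of compound 3 the step stays within the scatter (a 1.8-fold lower number from compound 3 to compound 4 (0.26 log units; within the scatter)), so compound 4 cannot be ranked above compound 3, and the change separates it only from the two six-membered rings with 1 hetero atom. No measured evidence accounts for this result.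

The compounds shown do not tell whether the second ring nitrogen or the methyl on it goes with the step, which an unsubstituted piperazin-1-yl or a morpholin-4-yl on the same carbonyl carbon would begin to separate. They also leave open how the number responds to a longer chain on that ring nitrogen, such as 4-ethylpiperazin-1-yl, or to a 4-acetylpiperazin-1-yl group.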